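A Second Fluorine on the Benzyl Ring of Compound 3

A few compounds are considered here, and "the series" means these few. Any claim that something is new, unique, unknown or untested is made for them only; others in the source may bear on it.

In a functional assay on BGC-823 cells (Homo sapiens) for antiproliferative activity, read by MTT assay, with a stated time of 24 h (a higher number here means a weaker inhibitor, a lower number a stronger inhibitor), compound 1 `c1ccc(CSc2nnc(-c3ccc4c(c3)OCCO4)n2-c2ccccc2)cc1` gives 73400 nM, compound 2 `Clc1cccc(CSc2nnc(-c3ccc4c(c3)OCCO4)n2-c2ccccc2)c1` gives 51200 nM and compound 3 `Fc1ccccc1CSc1nnc(-c2ccc3c(c2)OCCO3)n1-c1ccccc1` gives 18600 nM. Compound 3 therefore holds the lowest number of the three, separated from compound 2 by a 2.8-fold lower number from compound 2 to compound 3 (0.44 log units; beyond the scatter) and from compound 1 by a 3.9-fold lower number from compound 1 to compound 3 (0.60 log units; beyond the scatter), both beyond the scatter. Compound 4 `Fc1ccc(CSc2nnc(-c3ccc4c(c3)OCCO4)n2-c2ccccc2)c(F)c1` differs from compound 3 in one place: fluoro in place of hydrogen on an aromatic carbon. The new group sits on an aromatic carbon of a six-membered aromatic ring of carbon only, meta to a fluoro group and para to a large group. Among the measured compounds shown here, two measured steps bear on this change. Putting a fluoro in place of hydrogen on the same ring gave a 3.9-fold lower number from compound 1 to compound 3 (0.60 log units; beyond the scatter), a modest lowering, whereas putting a chloro in place of hydrogen gave a 1.4-fold lower number from compound 1 to compound 2 (0.16 log units; within the scatter), within the scatter. The expected step in this assay is a 1.7-fold lower number from compound 3 to compound 4 (0.23 log units; within the scatter), a modest lowering at most. Compound 4 is estimated at 11000 nM, with a range from 5000 nM to 28000 nM.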

Compound 4, half-maximal inhibitory concentration: > 100000 nM
Compound 4: no number, only a limit (the forecaster's own chance of this, stated with the estimate: 2%); middle value at least 9.0-fold (0.95 log units) away from the limit.
By their numbers in this assay, from the lowest: compound 3; then compounds 2 and 1 (each within the scatter of the next). At a limit, above all of these: compound 4.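

In this assay the reading for compound 4 is a limit and not a number: the limit of > 100000 nM in this assay, at which 1 of the 4 values shown sits. A fluoro on this aromatic carbon, meta to a fluoro group and para to a large group, gave an at least 5.3-fold higher number from compound 3 to compound 4 (0.73 log units; beyond the scatter), so on this ring a second fluoro went the opposite way to the first, which gave a 3.9-fold lower number from compound 1 to compound 3 (0.60 log units; beyond the scatter). How far compound 4 lies from the two remaining compounds is bounded only by floors, an at least 1.9-fold higher number from compound 2 to compound 4 (0.29 log units; that floor lies within the scatter) and an at least 1.3-fold higher number from compound 1 to compound 4 (0.13 log units; that floor lies within the scatter).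

The compounds shown leave open whether the rise belongs to fluoro itself or to any group on this carbon, such as a chloro, a methoxy or an amine. They also leave open whether this fluoro would have the same outcome on a ring without the first fluoro.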